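A Larger Alkoxy Group Tested Against Compound 1

A few compounds are considered here, and "the series" means these few. Any claim that something is new, unique, unknown or untested is made for them only; others in the source may bear on it.

Of the compounds shown here, two have numbers so far. Compound 1 `CCOc1cc(-c2cccnc2)ccc1C(N)=O` and compound 2 `Nc1ccc(-n2cnc(Cl)c2Cl)cc1` were both run in an assay on cells for inhibition of MAP kinase-interacting serine/threonine-protein kinase 1 (Homo sapiens), read by mobility shift assay, with stated times of 10 min and 60 min, in the presence of a further agent that is not named here; a lower number here means a stronger inhibitor, a higher number a weaker inhibitor. Compound 1 gives 2200 nM, the lowest number of the two, while compound 2 gives 103000 nM, a far higher value that lies well beyond the scatter, so compound 1 is the stronger inhibitor of this pair.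

Compound 3 `CC(C)Oc1cc(-c2cccnc2)ccc1C(N)=O` has not yet been measured. It differs from compound 1 in one place: methyl in place of hydrogen on a saturated chain carbon bound to an oxygen on an aromatic ring and a saturated chain carbon. Going by the values given here, no two measured compounds differ in just this way, so there is no measured step to lean on, only compound 1 at 2200 nM as the starting point. A change of this kind is expected to move the number little, if at all, beyond the scatter, in either direction. Compound 3 is therefore expected to come out near 2500 nM, between 800 nM and 8000 nM, which amounts to an expected step of a 1.1-fold higher number from compound 1 to compound 3 (0.06 log units; within the scatter).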

Compound 3, half-maximal inhibitory concentration: 880 nM
Compound 3: the middle estimate sits 2.8-fold (0.45 log units) above what was measured, within the range that was stated.
By their numbers in this assay, from the lowest: compound 3; then compound 1; then compound 2.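

Replacing ethoxy with isopropoxy adds a single methyl on the saturated chain carbon bound to the oxygen, and in this assay this gives a 2.5-fold lower number from compound 1 to compound 3 (0.40 log units; beyond the scatter). So this part of the core of compound 1 responds to a change of just one heavy atom, and here the larger group gives the stronger inhibitor, though only modestly. Nothing at hand explains why the number falls with this methyl.

This single step gives a direction for one change, not a trend with the size of the group on the oxygen. From the compounds shown here alone, whether a longer chain such as propoxy, or a bulkier tert-butoxy group, would lower the number further or raise it again remains open, as does the effect of a carboxylic acid in place of the amide.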